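The source may report more compounds than this note shows. Statements on the series, on what has been measured and on what is new or still open speak of the compounds shown alone.

Measured so far in a functional assay on P388 cells (Mus musculus) for inhibition; a lower number here means a stronger inhibitor, a higher number a weaker inhibitor:

- compound 1 `COCCOc1cc(/C=C\c2ccc3ccccc3c2)ccc1OC`: 2990 nM
- compound 2 `CC(=O)Oc1ccc(/C=C/c2ccc3ccccc3c2)cc1`: > 5000 nM (a limit)
- compound 3 `FC(F)(F)c1ccc(/C=C/c2ccc3ccccc3c2)cc1`: > 5000 nM (a limit)

Going by the values given here, compound 1 carries the only actual number. Compound 2 and compound 3 both sit at the limit of > 5000 nM in this assay, at which 2 of the 3 values shown sit, so each entry is a limit and not a number.

The next compound to be read is compound 4 `COc1ccc(/C=C\c2ccc3ccccc3c2)cc1[N+](=O)[O-]`, not yet measured. Relative to compound 1, the change is nitro in place of 2-methoxyethoxy on an aromatic carbon. Among the compounds with values here, the one measured step, a step that the two limits leave unreadable from compound 2 to compound 3, gives no size and involves neither the group that leaves nor the group that enters. Within the data shown here, no measured step therefore sizes this replacement, and no shift beyond the scatter is expected in this assay in either direction, though the uncertainty is wide and a reading at the limit is quite possible. The expected change is a 1.0-fold higher number from compound 1 to compound 4 (0.00 log units; within the scatter).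

The estimate for compound 4 is 3000 nM, with an expected range of 800 nM to 10000 nM.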

Compound 4, half-maximal inhibitory concentration: > 20000 nM
Compound 4 ended at the assay's limit; the forecaster's own chance of this, stated with the estimate: 35%; middle value at least 6.6-fold (0.82 log units) from the limit.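

In this assay, the aromatic carbon ortho to a methoxy group and meta to a large group proves sensitive to the group it carries: nitro in place of 2-methoxyethoxy gives an at least 6.6-fold higher number from compound 1 to compound 4 (0.82 log units; beyond the scatter). Going by these compounds alone, this is the first readable step, since the step between compound 2 and compound 3 cannot be read, and it shows that this replacement on the core of compound 1 is not neutral. The entry for compound 4 is a limit and not a number, so the step has a lower bound only: the limit of > 20000 nM in this assay, at which 1 of the 4 values shown sits.

Within the data shown here, with only two groups compared at this carbon, nothing yet separates the loss from nitro from any contribution of 2-methoxyethoxy itself. Still open, from the compounds shown here alone, is where an amine, a hydroxyl, a plain ethoxy or a longer ether chain at this carbon would fall relative to compound 1.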